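This account rests on a few compounds, and the source may have more. Where it says the series, first, only, none or still open, it means among the compounds named here.

Compound 3 `O=Cc1c(-c2ccc([N+](=O)[O-])cc2)nc2sc(Cc3ccccc3)nn12` gives 3700 nM in a functional assay on cells (Melanoma cell, Homo sapiens) for inhibition (on this read-out higher numbers stand for weaker inhibition of growth and lower numbers for stronger inhibition of growth), the lowest of the three numbers shown. Compound 2 `COc1ccc(-c2nc3sc(Cc4ccccc4)nn3c2SC#N)cc1` gives 5800 nM in this assay, a gap that lies within the scatter, whereas compound 1 `N#CSc1c(-c2ccccc2)nc2sc(Cc3ccccc3)nn12` gives 20900 nM, a gap beyond it. Among the compounds with values here, the only single-point step measured, a 3.6-fold lower number from compound 1 to compound 2 (0.56 log units; beyond the scatter), concerns the aryl ring, not the core. Compound 4 `O=[N+]([O-])c1ccc(-c2nc3sc(Cc4ccccc4)nn3c2Br)cc1` differs from compound 3 by bromo in place of formyl on an aromatic carbon. Within the data shown here, no measured step touches this position, so the expectation for compound 4 is a step about the size of the scatter, a 1.1-fold higher number from compound 3 to compound 4 (0.03 log units; within the scatter), with the direction uncertain. Compound 4 is therefore estimated at 4000 nM in this assay, within a range of 1200 nM to 13000 nM.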

Compound 4, concentration for 50% growth inhibition: 40700 nM
Compound 4: middle estimate off by 10-fold (1.01 log units), on the low side; measured number outside the range, above it.
By their numbers in this assay, from the lowest: compounds 3 and 2 (each within the scatter of the next); then compounds 1 and 4 (each within the scatter of the next).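

With bromo in place of formyl on this aromatic carbon, this assay shows an 11-fold higher number from compound 3 to compound 4 (1.04 log units; beyond the scatter), a large step. Within the data shown here, the earlier step concerned only the aryl ring, so this is the first sign that the group at this position of the five-membered aromatic ring matters to the read-out. Nothing shown explains the size of this step. Going by these compounds, with only formyl and bromo compared here, it stays open whether formyl helps or bromo hurts. On these data alone, how an amine, a carboxylic acid or a methyl group would fare at this position also remains open.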